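Nitro for fluoro on the aryl urea of compound 3

This account rests on a few compounds, and the source may have more. Where it says the series, first, only, none or still open, it means among the compounds named here.

Three cyanoaziridine ureas have been measured in a functional assay on A549 cells (Homo sapiens) for inhibition; on this read-out lower numbers stand for stronger inhibition and higher numbers for weaker inhibition. Compound 1 `CCOC(=O)CNC(=O)N1CC1C#N` carries an ethyl ester chain on the urea nitrogen, and in this assay compound 1 gives 24000 nM. Compound 2 `N#CC1CN1C(=O)Nc1ccc(Cl)c(Cl)c1` carries a dichlorophenyl group instead, and in this assay compound 2 gives 7500 nM. Compound 3 `N#CC1CN1C(=O)Nc1ccc(F)cc1` carries a fluorophenyl group, and in this assay compound 3 gives 6200 nM. Compound 3 thus shows the lowest number of the three, but its value and that of compound 2 lie within the scatter of each other, so no order between them can be claimed; only compound 1 stands clearly apart with a higher number.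

Compound 4 `N#CC1CN1C(=O)Nc1ccc([N+](=O)[O-])cc1` is the next member, differing from compound 3 by nitro in place of fluoro on an aromatic carbon. For the measured compounds named here, no measured pair in this set shows such an exchange, so there is no step on which to lean. The author expects compound 4 to stay near compound 3, with an estimated step of a 1.2-fold lower number from compound 3 to compound 4 (0.09 log units; within the scatter) that does not clearly leave the scatter. The author estimates that compound 4 will give 5000 nM in this assay, with a range from 1500 nM to 18000 nM.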

Compound 4, half-maximal inhibitory concentration: 3900 nM
Compound 4: middle estimate off by 1.3-fold (0.11 log units), on the high side; low and high end bracket the measured number.
By their numbers in this assay, from the lowest: compounds 4, 3 and 2 (each within the scatter of the next); then compound 1.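

In this assay, for the compounds shown here, nitro in place of fluoro gives a 1.6-fold lower number from compound 3 to compound 4 (0.20 log units; within the scatter), the first step in this set that changes a single place and so the first direct reading of this position on the aromatic ring, para to a group of 8 heavy atoms. The exchange replaces 1 heavy atom with 3 and adds 2 hydrogen-bond acceptors and 1 double bond outside aromatic rings, yet compound 4 stays within the scatter of compound 3, so this position accepts the larger group without a clear difference in the read-out, and no order can be claimed between the two compounds. Nothing measured here offers an explanation for this outcome.

Going by these compounds alone, with only this one exchange read, it remains open whether any group at this position, such as an amine, a carboxylic acid or a methoxy group, would move the number beyond the scatter. From the compounds shown here alone, it also remains open whether nitro would give a similar step on a ring that carries a second substituent, as the dichlorophenyl group of compound 2 does.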